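Chloro to Methyl on Two Related Cores

The compounds below may be only part of what the source reports. "The series", "measured", "known", "first", "only" and "open" are said of these compounds alone.

The set holds three measured compounds and one still to be measured. In an ADME assay on microsomes from liver (Mus musculus) for metabolic stability, read by LC-MS, using NADPH, with a stated time of 10 min, tested at 0.5 uM (a higher number here means that more of the compound is left, a lower number that less of the compound is left), compound 3 `CC(=O)Nc1cc(-c2ccc(OC[C@@H](N)CC(C)C)c(Cl)c2)ccn1` gives 86%. Compound 1 `CC(=O)Nc1cc(-c2ccc(OC[C@@H](N)CC(C)C)c(C)c2)ccn1` carries the change (methyl in place of chloro on an aromatic carbon). In this assay compound 1 gives 64%, and the step is a number 22 percentage points lower from compound 3 to compound 1 (beyond the scatter). Compound 2 `COC(=O)Nc1cc(-c2cc(Cl)c(OC[C@@](C)(N)CC(C)C)cn2)ccn1` gives 87% in this assay; the difference between its core and that of compound 3 is not broken down here. Compound 4 `COC(=O)Nc1cc(-c2cc(C)c(OC[C@@](C)(N)CC(C)C)cn2)ccn1` is not yet measured and differs from compound 2 by the change (methyl in place of chloro on an aromatic carbon). The surroundings are not identical: in compound 1 the ring is of carbon only and the change sits ortho to a (2-amino-4-methylpentyl)oxy group, while in compound 4 the ring holds one nitrogen and the change sits ortho to a (2-amino-2,4-dimethylpentyl)oxy group and opposite the ring nitrogen, so this is the same kind of change, not the same. A step of similar size is expected, a number 20 percentage points lower from compound 2 to compound 4 (beyond the scatter), because a number 22 percentage points lower from compound 3 to compound 1 (beyond the scatter) was observed. Compound 4 is therefore estimated at 67%, between 50% and 82%.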

Compound 4, percent of the compound remaining: 99%
The estimate for compound 4 lay 32 percentage points below the measured number; measured number outside the range, above it.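

In this assay, the exchange of chloro for methyl did not carry over from one core to the other, and on the core of compound 2 it gave a number 12 percentage points higher from compound 2 to compound 4 (beyond the scatter). The two steps point in opposite directions and do not agree: the same change on two cores in this assay, a number 22 percentage points lower (beyond the scatter) from compound 3 to compound 1 and a number 12 percentage points higher (beyond the scatter) from compound 2 to compound 4, 34 percentage points apart, beyond the scatter of two such steps This shows that, among the compounds shown, the step on one core was no guide to the step on the other, but two pairs do not show which difference between the cores goes with the reversal, nor how the exchange would behave on any further core.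

The compounds shown do not separate the ring nitrogen from the change of the (2-amino-4-methylpentyl)oxy group to the (2-amino-2,4-dimethylpentyl)oxy group, so either one, the two together or another difference between the cores could go with the reversal. Also open, from the compounds shown here alone, is how a fluoro, trifluoromethyl or ethyl group would compare with chloro and methyl at this place on either core.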